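The source may report more compounds than this note shows. Statements on the series, on what has been measured and on what is new or still open speak of the compounds shown alone.

The compounds measured so far:
compound 1, `ClCc1cccc(Cn2cnc3c(Cl)ncnc32)c1`, which in a functional assay on A549 cells (Homo sapiens) for cytotoxicity, read by sulforhodamine B assay, with a stated time of 48 h (a higher number here means that more compound is tolerated, a lower number that less compound is tolerated), gives 79400 nM;
compound 2, `ClCc1cccc(Cn2cnc3c(Cl)nc(Cl)nc32)c1`, which in this assay gives 52500 nM;
compound 3, `ClCc1ccccc1Cn1cnc2ncnc(Cl)c21`, for which this assay reports only a limit, > 100000 nM, and not a number.

Compound 2 holds the lowest of the two numbers available, and its nearest neighbour is compound 1, reached by the step of a 1.5-fold lower number from compound 1 to compound 2 (0.18 log units; within the scatter), which stays within the scatter. The third value is the limit of > 100000 nM in this assay, at which 1 of the 3 values shown sits.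

Compound 4, `Nc1nc(Cl)c2ncn(Cc3cccc(CCl)c3)c2n1`, differs from compound 2 by amino in place of chloro on an aromatic carbon. Among the measured compounds shown here, only one measured step exists, and it concerns the same place: in a 1.5-fold lower number from compound 1 to compound 2 (0.18 log units; within the scatter) a chloro replaced a hydrogen there, with no change beyond the scatter. For the measured compounds named here, no measured pair involves an amino anywhere on the shared core, so nothing directly tells how swapping chloro for amino will act. The expectation for compound 4 in this assay is therefore a small step of no settled direction, a 1.3-fold higher number from compound 2 to compound 4 (0.12 log units; within the scatter), with a wide range because the nearby the limit of > 100000 nM in this assay, at which 1 of the 3 values shown sits, may again be all that is reported. Compound 4 is estimated at 70000 nM, between 25000 nM and 100000 nM.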

Compound 4, concentration lethal to 50% of the cells: 63100 nM
The estimate for compound 4 lay 1.1-fold (0.05 log units) above the measured number; the range from low to high includes it.
By their numbers in this assay, from the lowest: compounds 2, 4 and 1 (each within the scatter of the next). At a limit, above all of these: compound 3.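

Until now this position, between two ring nitrogen atoms, had shown only chloro in place of hydrogen; amino is a different kind of group, with nitrogen in place of chlorine and a hydrogen-bond donor that chloro lacks. Even so, this assay separates neither pair of compounds (a 1.2-fold higher number from compound 2 to compound 4 (0.08 log units; within the scatter); a 1.3-fold lower number from compound 1 to compound 4 (0.10 log units; within the scatter)), so hydrogen, chloro and amino at this position cannot be told apart in this read-out, and all three steps stay within the scatter. The limit reported for compound 3 has no bearing on this position, and nothing shown explains why these three groups read alike.

Going by these compounds, it remains open whether a larger group at this position, such as a dimethylamino group, a methoxy group or a longer amine chain, or a carboxylic acid, would move the number beyond the scatter. Compound 1, compound 2 and compound 4 also all carry the same chloromethyl group, so what happens when a methyl or hydroxymethyl group stands in its place is equally unanswered.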